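Swapping the Amide Substituent in an Inactive Sulfonamide Series

The compounds below may be only part of what the source reports. "The series", "measured", "known", "first", "only" and "open" are said of these compounds alone.

Compound 1 `CCN(CC)S(=O)(=O)c1ccc(S(=O)(=O)N2CCC[C@@H](C(=O)N3CCC(O)CC3)C2)cc1` gives > 10000 nM in a functional assay on MIA PaCa-2 cells (Homo sapiens) for inhibition, read by MTT assay, with a stated time of 3 days (on this read-out lower numbers stand for stronger inhibition and higher numbers for weaker inhibition), which is a limit of the assay and not a number.
Compound 2 `CCN(CC)S(=O)(=O)c1ccc(S(=O)(=O)N2CCC[C@@H](C(=O)N3CCOCC3)C2)cc1` gives > 10000 nM in this assay, again a limit.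
Compound 3 `CC(C)S(=O)(=O)c1ccc(S(=O)(=O)N2CCC[C@@H](C(=O)N3CCC(F)(F)CC3)C2)cc1` gives > 3000 nM in this assay, also a limit.

Compound 1 therefore stands only at a limit, and the other two values shown are limits as well (the limit of > 10000 nM in this assay, at which 2 of the 3 values shown sit, (the limit of > 3000 nM in this assay, at which 1 of the 3 values shown sits)). Compound 4 `CCN(CC)S(=O)(=O)c1ccc(S(=O)(=O)N2CCC[C@@H](C(=O)N[C@@H]3CCOC3)C2)cc1` differs from compound 1 by (oxolan-3-yl)amino in place of 4-hydroxypiperidin-1-yl on a carbonyl carbon. Among the measured compounds shown here, the one measured step at the same carbonyl position, a step that the two limits leave unreadable from compound 1 to compound 2, has both ends at a limit and so yields no size and no direction. Nothing beyond the usual scatter can be expected in this assay from what is shown. Compound 4 is expected to give 15000 nM, between 5000 nM and 50000 nM. This step is expected to be a step that the limit leaves unreadable from compound 1 to compound 4.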

Compound 4, half-maximal inhibitory concentration: > 10000 nM
Compound 4: only a limit was reported; the forecaster's own chance of this, stated with the estimate: 80%; the middle value lies beyond the limit too.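

No step can be read among compound 1, compound 2 and compound 4, because all three sit at the same limit of the assay, not at a number: the limit of > 10000 nM in this assay, at which 3 of the 4 values shown sit.

The compounds shown leave open whether any group on the carbonyl carbon gives a measurable value.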